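A few compounds are considered here, and "the series" means these few. Any claim that something is new, unique, unknown or untested is made for them only; others in the source may bear on it.

Working notes on the series. The shared core is carried by compound 1 `Cc1ccc2c(c1)C(=O)/C(=C(\S)N(C)c1ccccc1)C(=O)N2C`, compound 2 `CN1C(=O)/C(=C(/S)N(C)c2ccccc2)C(=O)c2cc(Br)ccc21` and compound 3 `COCCCN(/C(S)=C1/C(=O)c2cc(Cl)ccc2N(C)C1=O)c1ccccc1`. In a functional assay on the whole organism for inhibition, with Mus musculus as the target, at a dose of 10 mg/kg by the oral route (on this read-out lower numbers stand for less inhibition and higher numbers for more inhibition at the one dose given (going by the name of the read-out)), compound 1 gives 20%, compound 2 gives 56% and compound 3 gives 31%. Compound 2 thus stands highest of the three numbers in this assay: its nearest neighbour is compound 3, lower by a margin beyond the scatter, and the furthest is compound 1, lower by a larger margin, also beyond the scatter. Going by the values given here, the one single-point step measured so far is from compound 1 to compound 2, where bromo in place of methyl on an aromatic carbon gives a number 36 percentage points higher from compound 1 to compound 2 (beyond the scatter), a large gain. Among the compounds with values here, compound 2 and compound 3 differ in two places at once, so their two values show only that compound 3 sits lower.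

Compound 4 `CN1C(=O)/C(=C(/S)N(C)c2ccccc2)C(=O)c2cc(-n3cccc3)ccc21` is not yet measured. Relative to compound 2 the change is 1H-pyrrol-1-yl in place of bromo on an aromatic carbon. Within the data shown here, the step from compound 1 to compound 2 bears on it only in that the same aromatic carbon is touched; no measured step replaces bromo with a group of this kind. Because the only large gain in this assay came with bromo itself, a number 36 percentage points higher from compound 1 to compound 2 (beyond the scatter), losing bromo is expected to cost part of that gain, a step of moderate size downward, a number 16 percentage points lower from compound 2 to compound 4 (beyond the scatter). Compound 4 is estimated at 40%, within a range from 15% to 65%.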

Compound 4, a percentage reported as inhibition, in the whole organism at one dose (the size of the read-out at that dose, not a potency): -10%
For compound 4 the middle estimate is 50 percentage points above the measured one; the whole stated range lies above it.
By their numbers in this assay, from the lowest: compound 4; then compound 1; then compound 3; then compound 2.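

In this assay 1H-pyrrol-1-yl in place of bromo on this aromatic carbon gives a number 66 percentage points lower from compound 2 to compound 4 (beyond the scatter) and 1H-pyrrol-1-yl in place of methyl gives a number 30 percentage points lower from compound 1 to compound 4 (beyond the scatter) so this position does more than separate bromo from methyl: a third group falls under both. Compound 4 gives -10% as its number, which is less than zero, so this read-out at the one dose can go negative, and the three groups on this carbon run from 1H-pyrrol-1-yl through methyl to bromo, going up. The change replaces a single bromine atom with a five-membered aromatic ring of five heavy atoms, and nothing measured in this series gives a reason for the fall.

The compounds shown leave open where a fluoro, a methoxy, an amino group or a saturated pyrrolidin-1-yl ring on this aromatic carbon would fall in that order. They also leave open whether the low number goes with the aromatic ring itself or with any group of this number of heavy atoms.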